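The compounds below may be only part of what the source reports. "The series", "measured", "known", "first", "only" and "open" are said of these compounds alone.

Measured so far in a functional assay on HepG2 cells (Homo sapiens) for cytotoxicity, read by MTT assay, with a stated time of 24 h; a higher number here means a weaker inhibitor, a lower number a stronger inhibitor:
compound 1 `COc1cc(/C=C2\CN(C)C/C(=C\c3ccc(Cl)c(Cl)c3)C2=O)cc(OC)c1` gives 3840 nM
compound 2 `COc1cc(/C=C2\CN(C)C/C(=C\c3ccc(F)cc3)C2=O)cc(OC)c1OC` gives 7340 nM

Compound 2 at 7340 nM and compound 1 at 3840 nM lie within the usual scatter of each other, so neither stands apart on these numbers. The next compound to read is compound 3 `COc1cc(/C=C2\CN(C)C/C(=C\c3ccc(Cl)c(Cl)c3)C2=O)cc(OC)c1OC` which differs from compound 2 by 3,4-dichlorophenyl in place of 4-fluorophenyl on a double-bonded chain carbon bound to a double-bonded ring carbon and has 3,4-dichlorophenyl in place of 4-fluorophenyl on a double-bonded chain carbon bound to a double-bonded ring carbon.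

Going by the values given here, no measured step isolates this change, so the expectation rests on thin evidence. Among the compounds with values here, the expectation in this assay is a small drop in the number, resting on compound 1 at 3840 nM as the one measured compound that also carries 3,4-dichlorophenyl. The step of a 1.6-fold lower number from compound 2 to compound 3 (0.21 log units; within the scatter) is expected to be modest and may well stay within the scatter. For compound 3 the estimate is 4500 nM with an expected range from 2000 nM to 10000 nM as the likely span of the result.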

Compound 3, half-maximal inhibitory concentration: 6960 nM
Beside the measured number, compound 3's estimate is 1.5-fold (0.19 log units) below it; measured number inside the range.
By their numbers in this assay, from the lowest: compounds 1, 3 and 2 (each within the scatter of the next).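

In this assay, the exchange of 4-fluorophenyl for 3,4-dichlorophenyl on a double-bonded chain carbon bound to a double-bonded ring carbon now has a measured step of its own (a 1.1-fold lower number from compound 2 to compound 3 (0.02 log units; within the scatter)), so with the rest of the structure held constant, these two groups cannot be told apart at this position. The second single-place pair holds 3,4-dichlorophenyl fixed and tests methoxy in place of hydrogen on an aromatic carbon (a 1.8-fold higher number from compound 1 to compound 3 (0.26 log units; within the scatter)), and this change also gives no separation beyond the scatter. No measurement at hand bears on the reason for either reading.

The compounds shown leave open whether a phenyl group carrying an amine or a carboxylic acid on this double-bonded chain carbon would move the number beyond the scatter. They also leave open whether a longer alkoxy chain in place of methoxy on the aromatic carbon would separate from hydrogen and methoxy, since these two substituents are the only ones compared at that place.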